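A few compounds are considered here, and "the series" means these few. Any claim that something is new, unique, unknown or untested is made for them only; others in the source may bear on it.

Of the compounds shown here, three of one series have been tested so far: compound 1 `Cc1nc2nc(SCc3ccc(Cl)cc3)nn2c(N2CC[C@@H](C)[C@@H](N(C)c3ncnc4[nH]ccc34)C2)c1C`, compound 2 `Cc1cc(N2CC[C@@H](C)[C@@H](N(C)c3ncnc4[nH]ccc34)C2)n2nc(SCc3ccc(F)cc3)nc2n1` and compound 3 `CCc1cc(N2CC[C@@H](C)[C@@H](N(C)c3ncnc4[nH]ccc34)C2)n2ncnc2n1`. In a toxicity assay on GES1 cells (Homo sapiens) for inhibition, read by MTT assay, with a stated time of 72 h (a lower number here means a stronger inhibitor, a higher number a weaker inhibitor), compound 1 gives 99200 nM, while compound 2 gives 12300 nM. For compound 3 the result in this assay is only a limit, > 100000 nM, not a number. Among the two numbers, compound 2 stands lowest; compound 1 sits higher by a margin that is beyond the usual scatter, and compound 3 cannot be placed against either because its value is a limit.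

The next compound, compound 4 `CCCSc1nc2nc(C)cc(N3CC[C@@H](C)[C@@H](N(C)c4ncnc5[nH]ccc45)C3)n2n1`, keeps the core of compound 2 and changes only the group on the sulfur side chain: ethyl in place of 4-fluorophenyl on a saturated chain carbon bound to a sulfur. For the measured compounds named here, no pair of measured compounds differs by exactly this change, so the size of the step has to be expected rather than read off. Given that compound 3, which carries no sulfanyl arm at all, reaches only the limit (the limit of > 100000 nM in this assay, at which 1 of the 3 values shown sits), the move from compound 2 to compound 4 is expected to shift the number upward, beyond the scatter but short of the limit, with the expected step being a 3.3-fold higher number from compound 2 to compound 4 (0.51 log units; beyond the scatter). Compound 4 is accordingly estimated at 40000 nM in this assay, with a range from 15000 nM to 100000 nM.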

Compound 4, half-maximal inhibitory concentration: 67100 nM
For compound 4 the middle estimate is 1.7-fold (0.22 log units) below the measured one; the measured number falls inside the stated range.
By their numbers in this assay, from the lowest: compound 2; then compounds 4 and 1 (each within the scatter of the next). At a limit, above all of these: compound 3.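

For the compounds shown here, this is the only single change that can be read directly: in this assay, ethyl in place of 4-fluorophenyl on a saturated chain carbon bound to a sulfur gives a 5.5-fold higher number from compound 2 to compound 4 (0.74 log units; beyond the scatter). The number at this position therefore responds to the group carried there, and cut one bond further out, the change from (4-fluorobenzyl)sulfanyl to propylsulfanyl removes the aromatic ring yet leaves compound 4 with a measured number rather than a limit. Compound 3 alone stays at a limit, which is not a number: the limit of > 100000 nM in this assay, at which 1 of the 4 values shown sits.

One step cannot show whether the rise follows from losing the ring, losing the fluorine or simply having fewer heavy atoms in the arm. Plain benzyl would separate the ring from the fluorine at this place, while a longer chain such as butyl or a propyl chain ending in an amine would show how far the number in this assay moves among arms without a ring.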